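The compounds below may be only part of what the source reports. "The series", "measured", "known", "first", "only" and "open" are said of these compounds alone.

Of the compounds shown here, two with a shared core have been measured so far. Compound 1 `Cc1c(S(=O)(=O)n2ccc3c(N4CCNCC4)cccc32)sc2ccc(Cl)cc12` carries a substituted bicyclic aromatic group on the sulfonyl sulfur, and in an assay on HeLa cells for displacement of a labelled ligand from 5-hydroxytryptamine receptor 6 (Homo sapiens) (on this read-out higher numbers stand for weaker inhibition and lower numbers for stronger inhibition), compound 1 gives 3.16 nM. Compound 2 `O=S(=O)(c1ccccc1)n1ccc2c(N3CCNCC3)c(Cl)ccc21` carries a plain phenyl on that sulfur instead, and in this assay compound 2 gives 1.59 nM. These two numbers sit close together, within the scatter that repeated measurements of this kind usually show, so nothing can be said about which of the two binds more tightly. The new compound 3 `O=S(=O)(c1ccccn1)n1ccc2c(N3CCNCC3)c(Cl)ccc21` keeps everything in compound 2 except one group: pyridin-2-yl in place of phenyl on a sulfonyl sulfur. For the measured compounds named here, no measured pair shows what this particular swap does. Because compound 2 gives 1.59 nM and the swap replaces one six-membered aromatic ring with another of the same size, the expected step from compound 2 to compound 3 is small, a 1.6-fold higher number from compound 2 to compound 3 (0.20 log units; within the scatter), and may not rise beyond the scatter. Compound 3 is therefore expected to give about 2.5 nM in this assay, with a likely range from 0.8 nM to 8 nM.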

Compound 3, inhibition constant: 0.501 nM
Compound 3: middle estimate off by 5.0-fold (0.70 log units), on the high side, and the stated range ends above it.
By their numbers in this assay, from the lowest: compound 3; then compounds 2 and 1 (each within the scatter of the next).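

In this assay, pyridin-2-yl in place of phenyl on a sulfonyl sulfur gives a 3.2-fold lower number from compound 2 to compound 3 (0.50 log units; beyond the scatter), so this is the first change among these compounds whose effect can be read beyond the scatter. The two groups are alike in ring size and heavy-atom count, and they differ in one ring carbon being replaced by nitrogen, which adds a hydrogen-bond acceptor, so at this place even a single-atom change within the ring is enough to move the number. Nothing measured here explains why the number moves.

The compounds shown leave open whether the step depends on where the nitrogen sits in the ring, which pyridin-3-yl or pyridin-4-yl on the same sulfur would show, and whether a ring with a second nitrogen, such as pyrimidin-2-yl, would move the number further. They also leave open whether pyridin-2-yl on the sulfonyl sulfur would give a step of similar size on the core of compound 1, which lacks the chlorine placed as in compound 2.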